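The source may report more compounds than this note shows. Statements on the series, on what has been measured and on what is new or still open speak of the compounds shown alone.

Compound 1 `C=C(CCCCCCC)c1c(C)[nH]c2ccccc2c1=O` gives 1760 10^-6 cm/s
Compound 2 `Cc1[nH]c2ccccc2c(=O)c1/C=C/C(=O)OC(C)(C)C` gives 105 10^-6 cm/s

In an ADME assay for permeability, using PAMPA, at pH 4 (on this read-out lower numbers stand for lower permeability and higher numbers for higher permeability), only these two compounds have been measured so far. Compound 2 holds the lower of the two numbers, and compound 1 lies above it by a gap beyond the usual scatter of repeated measurements. The two differ in more than one place, so that gap says nothing about any single change.

Compound 3 `Cc1[nH]c2ccccc2c(=O)c1/C=C/c1ccc(O)cc1` has not yet been measured. It differs from compound 2 in one place 4-hydroxyphenyl in place of tert-butoxycarbonyl on a double-bonded chain carbon bound to a double-bonded chain carbon with 4-hydroxyphenyl in place of tert-butoxycarbonyl on a double-bonded chain carbon bound to a double-bonded chain carbon.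

Going by the values given here, no measured pair shows what this exchange does, so the expectation is only loosely founded. It starts from compound 2 at 105 10^-6 cm/s as the closest measured reference. No step beyond the scatter is expected, and the estimated move is small (a 1.3-fold lower number from compound 2 to compound 3 (0.12 log units; within the scatter)) with wide uncertainty in either direction. The expected value for compound 3 is 80 10^-6 cm/s with an estimated range from 20 10^-6 cm/s to 320 10^-6 cm/s as the likely span.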

Compound 3, apparent permeability: 10.7 10^-6 cm/s
For compound 3 the middle estimate is 7.5-fold (0.87 log units) above the measured one; measured number below the stated range.
By their numbers in this assay, from the lowest: compound 3; then compound 2; then compound 1.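

In this assay, going by these compounds alone, 4-hydroxyphenyl in place of tert-butoxycarbonyl on a double-bonded chain carbon bound to a double-bonded chain carbon is the first change that can be read on its own (a 9.8-fold lower number from compound 2 to compound 3 (0.99 log units; beyond the scatter)). The earlier pair differed in more than one place, so only now is it clear that the read-out answers to a single exchange at this position, and it does so even though the two groups count the same number of heavy atoms. The entering group brings an aromatic ring and a hydrogen-bond donor that the leaving group lacks, but no measurement here explains the fall in the number.

The compounds shown leave open whether the step follows the hydroxyl or the aromatic ring, a question that plain phenyl or 4-methoxyphenyl on the same carbon would separate. They also leave open what a carboxylic acid or an amine at this position would give in this assay.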